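A few compounds are considered here, and "the series" means these few. Any claim that something is new, unique, unknown or untested is made for them only; others in the source may bear on it.

- Compound 1 `Nc1oncc1-c1ccccc1`: 0%
- Compound 2 `CNc1oncc1-c1ccccc1`: 0.1%

In an ADME assay on blood (Canis lupus familiaris) for metabolic stability, read by LC-MS, with a stated time of 2 h, tested at 0.5 mM (on this read-out higher numbers stand for a more stable compound and lower numbers for a less stable compound), compound 1 gives 0%, level with compound 2 within the scatter. Compound 3 `Cc1noc(N)c1-c1ccccc1` differs from compound 1 by methyl in place of hydrogen on an aromatic carbon: a methyl in place of hydrogen on an aromatic carbon, next to the ring nitrogen. Among the compounds with values here, the only measured step, a number 0.1 percentage points higher from compound 1 to compound 2 (within the scatter), placed a methyl on a nitrogen instead, so it bears only weakly on this change. From the compounds shown here alone, both measured compounds keep the hydrogen that compound 3 loses, so the effect of replacing it is unknown. Compound 1 has 0%, which leaves room for movement only upward. The expected result, with much uncertainty, is a number 40 percentage points higher from compound 1 to compound 3 (beyond the scatter). For compound 3 the estimated value is 40%, with an expected range from 2% to 90%.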

Compound 3, percent of the compound remaining: 65%
For compound 3 the middle estimate is 25 percentage points below the measured one, within the range that was stated.
By their numbers in this assay, from the lowest: compounds 1 and 2 (each within the scatter of the next); then compound 3.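

In this assay, methyl in place of hydrogen on this aromatic carbon gives a number 65 percentage points higher from compound 1 to compound 3 (beyond the scatter) and so lifts the compound clear of the bottom of the scale. Methyl on the nitrogen gave only a number 0.1 percentage points higher from compound 1 to compound 2 (within the scatter) in the earlier step, so in these compounds the place of the methyl decides the outcome. No measurement shown here explains the rise. From the compounds shown here alone, whether a larger group at this carbon, such as ethyl or a longer chain, would give a higher or lower number remains open. So does whether a chlorine atom there would match the methyl.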